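This account rests on a few compounds, and the source may have more. Where it says the series, first, only, none or still open, it means among the compounds named here.

Compound 3 `CCN(CC)C(=O)c1ccc(S(=O)(=O)N2CCC[C@@H](C(=O)N3CCN(c4nc(C(C)C)no4)CC3)C2)cc1` gives 70 nM in a functional assay on MIA PaCa-2 cells (Homo sapiens) for inhibition, read by MTT assay, with a stated time of 3 days (on this read-out higher numbers stand for weaker inhibition and lower numbers for stronger inhibition), the highest of the two numbers shown. Compound 2 `CC(C)c1noc(N2CCN(C(=O)[C@@H]3CCCN(S(=O)(=O)c4ccc(S(=O)(=O)C5CCC5)cc4)C3)CC2)n1` gives 20 nM in this assay; between them lies the step of a 3.5-fold higher number from compound 2 to compound 3 (0.54 log units; beyond the scatter). Compound 1 `CCOC(=O)[C@H]1CCN(S(=O)(=O)c2ccc(S(=O)(=O)N(CC)CC)cc2)C1` returns only a limit in this assay, > 10000 nM. Compound 4 `CC(C)c1noc(N2CCN(C(=O)[C@@H]3CCCN(S(=O)(=O)c4ccc(S(=O)(=O)C(C)C)cc4)C3)CC2)n1` differs from compound 3 by isopropylsulfonyl in place of diethylcarbamoyl on an aromatic carbon. For the measured compounds named here, this change places a sulfonyl group on that aromatic carbon again, as in compound 2, so the one measured step that bears on it is a 3.5-fold higher number from compound 2 to compound 3 (0.54 log units; beyond the scatter), and a step of similar size in the opposite direction is expected from compound 3 to compound 4, a 2.8-fold lower number from compound 3 to compound 4 (0.45 log units; beyond the scatter). Compound 4 is therefore estimated at 25 nM in this assay, with a range from 10 nM to 60 nM.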

Compound 4, half-maximal inhibitory concentration: 30 nM
Compound 4: middle estimate off by 1.2-fold (0.08 log units), on the low side, and the stated range covers the measured number.
By their numbers in this assay, from the lowest: compounds 2 and 4 (each within the scatter of the next); then compound 3. At a limit, above all of these: compound 1.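

For the compounds shown here, with a 2.3-fold lower number from compound 3 to compound 4 (0.37 log units; beyond the scatter) in this assay, isopropylsulfonyl on this aromatic carbon gives a lower number than diethylcarbamoyl, so compound 2 is no longer the only sulfonyl example to do so. The group on the sulfonyl sulfur can change from cyclobutyl to isopropyl without a clear difference, as a 1.5-fold higher number from compound 2 to compound 4 (0.18 log units; within the scatter) stays within the usual scatter. Nothing measured here explains either result. As far as these compounds go, it remains open how an amine or a carboxylic acid would fare on this aromatic carbon. A longer chain on the sulfonyl sulfur also remains untested in the compounds shown.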